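Methyl for chloro on the anilide ring

This account rests on a few compounds, and the source may have more. Where it says the series, first, only, none or still open, it means among the compounds named here.

Compound 1 `COc1ccc2c(=O)c(/C=C/C(=O)Nc3cc(C)ccc3C)coc2c1`: 15500 nM
Compound 2 `COc1ccc2c(=O)c(/C=C/C(=O)Nc3ccc(Cl)cc3)coc2c1`: > 100000 nM

In a functional assay on A549 cells (Homo sapiens) for inhibition, read by MTT assay, with a stated time of 48 h (a higher number here means a weaker inhibitor, a lower number a stronger inhibitor), compound 1 gives 15500 nM. For compound 2 the assay reports only a limit, > 100000 nM. Within the data shown here, the single measured step, an at least 6.4-fold higher number from compound 1 to compound 2 (0.80 log units; beyond the scatter), carried the value onto (the limit of > 100000 nM in this assay, at which 1 of the 2 values shown sits). Compound 3 `COc1ccc2c(=O)c(/C=C/C(=O)Nc3ccc(C)cc3)coc2c1` differs from compound 2 by methyl in place of chloro on an aromatic carbon. Among the measured compounds shown here, no measured step covers this exact exchange; the only guide is that compound 1, carrying 2,5-dimethylphenyl, gave a number while compound 2 stood on the limit. Compound 3 is therefore expected between the two, at 50000 nM with a range of 15000 nM to 200000 nM. The implied step, an at least 2.0-fold lower number from compound 2 to compound 3 (0.30 log units; that floor lies within the scatter), is an estimate only, and a limit reading remains quite possible.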

Compound 3, half-maximal inhibitory concentration: 17500 nM
The estimate for compound 3 lay 2.9-fold (0.46 log units) above the measured number; the measured number falls inside the stated range.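

Methyl in place of chloro on this aromatic carbon is enough to bring the number off the limit, with an at least 5.7-fold lower number from compound 2 to compound 3 (0.75 log units; beyond the scatter). The 4-methylphenyl and 2,5-dimethylphenyl groups read alike, with a 1.1-fold higher number from compound 1 to compound 3 (0.05 log units; within the scatter), so the 2,5-dimethyl pattern is not needed for a measurable number. Compound 2 stands on a limit of the assay, so that first step is only a floor: the limit of > 100000 nM in this assay, at which 1 of the 3 values shown sits.

The compounds shown leave open how fluoro, methoxy or an amine would read at this place. They also leave open whether a longer chain such as ethyl would read like methyl.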